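Swapping Methyl for Hydrogen on an Ester Oxygen

The source may report more compounds than this note shows. Statements on the series, on what has been measured and on what is new or still open speak of the compounds shown alone.

Of the compounds shown here, three have been tested in a functional assay on A549 cells (Homo sapiens) for cytotoxicity, read by CCK-8 assay, with a stated time of 72 h; on this read-out higher numbers stand for weaker inhibition and lower numbers for stronger inhibition. Compound 2 `COC(=O)CC1CNC(=O)c2cc(Br)c(Br)n21` gives 82000 nM. Compound 3 `COC(=O)CC1CNC(=O)c2ccc(Br)n21` gives 65000 nM. Compound 1 `O=C(O)CC1CNC(=O)c2cc(Br)c(Br)n21` reaches only a limit of the assay, > 200000 nM, which is not a number. The two cores differ by hydrogen in place of bromo on an aromatic carbon; the step of a 1.3-fold lower number from compound 2 to compound 3 (0.10 log units; within the scatter) lies within the scatter, so the two numbers are taken as alike. Compound 1 is made from compound 2 by hydrogen in place of methyl on an oxygen next to a carbonyl group, and this gave an at least 2.4-fold higher number from compound 2 to compound 1 (0.38 log units; beyond the scatter); the step is open-ended because compound 1 sits at the limit of > 200000 nM in this assay, at which 1 of the 3 values shown sits. Compound 4 `O=C(O)CC1CNC(=O)c2ccc(Br)n21` is not yet measured. For the measured compounds named here, it is made from compound 3 by hydrogen in place of methyl on an oxygen next to a carbonyl group, the same change as the one from compound 2 to compound 1, at the same place on each core. Compound 4 is therefore expected to show a 2.8-fold higher number from compound 3 to compound 4 (0.44 log units; beyond the scatter) in this assay. That expectation rests on the step of an at least 2.4-fold higher number from compound 2 to compound 1 (0.38 log units; beyond the scatter) and on compound 3 giving 65000 nM. The estimate for compound 4 is 180000 nM, with a range from 80000 nM to 400000 nM, and a fair chance that only a limit is reported.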

Compound 4, half-maximal inhibitory concentration: > 200000 nM
Compound 4: no number, only a limit (the forecaster's own chance of this, stated with the estimate: 60%); at least 1.1-fold (0.04 log units) between middle value and limit.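

In this assay, the change from methoxycarbonyl to carboxy again gives weaker inhibition, with an at least 3.0-fold higher number from compound 3 to compound 4 (0.48 log units; beyond the scatter), so the direction seen on the core of compound 1 also holds on the core of compound 4. This shows that the direction carries over, but not that the size does, and the two steps can only be set side by side as open-ended ones: the same change on two cores in this assay, an at least 2.4-fold higher number (0.38 log units; beyond the scatter) from compound 2 to compound 1 and an at least 3.0-fold higher number (0.48 log units; beyond the scatter) from compound 3 to compound 4; the limit leaves it open whether they differ. The step between the two carboxy compounds, compound 1 and compound 4, cannot be read, so these compounds do not show whether the extra bromo matters once the carboxy group is present: the limit of > 200000 nM in this assay, at which 2 of the 4 values shown sit.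

From the compounds shown here alone, how weak compound 1 and compound 4 really are remains open, as a limit gives no actual number for either. Also open, going by these compounds, is how other groups in place of the methoxycarbonyl, such as an ethyl ester, an amide or a longer chain, would compare with compound 2 and compound 3 on these two cores.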